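Thiophene Carboxamide in Place of Acetamide on a Chalcone

The compounds below may be only part of what the source reports. "The series", "measured", "known", "first", "only" and "open" are said of these compounds alone.

Measured compounds:
compound 1, `O=C(/C=C/c1ccccc1)c1ccc(NC(=O)c2cccs2)cc1`, 35000 nM
compound 2, `CC(=O)Nc1ccc(C(=O)/C=C/c2cccc([N+](=O)[O-])c2)cc1`, 6300 nM

Of the compounds shown here, two have been measured in a functional assay on DLD-1 cells (Homo sapiens) for cytotoxicity, read by resazurin assay, with a stated time of 48 h; a higher number here means that more compound is needed for the effect, a lower number that less compound is needed. Compound 1 gives 35000 nM in this assay, and compound 2 gives 6300 nM. Going by the values given here, compound 2 therefore stands at the lowest of the two numbers; the only other number, that of compound 1, is higher and the gap lies beyond the scatter. The next compound, compound 3 with the structure `O=C(/C=C/c1cccc([N+](=O)[O-])c1)c1ccc(NC(=O)c2cccs2)cc1`, is not yet measured. It differs from compound 2 in one place: thiophen-2-yl in place of methyl on a carbonyl carbon. Among the compounds with values here, no measured pair shows this particular change on its own, so its size cannot be read from the data. The expectation is a small step from compound 2 to compound 3, of uncertain direction and possibly within the scatter. For compound 3 in this assay the estimated value is 8000 nM, with a range from 2500 nM to 25000 nM. The expected step is a 1.3-fold higher number from compound 2 to compound 3 (0.10 log units; within the scatter).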

Compound 3, half-maximal effective concentration: 11000 nM
For compound 3 the middle estimate is 1.4-fold (0.14 log units) below the measured one; measured number inside the range.
By their numbers in this assay, from the lowest: compounds 2 and 3 (each within the scatter of the next); then compound 1.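

In this assay, thiophen-2-yl in place of methyl on the carbonyl carbon gives a 1.7-fold higher number from compound 2 to compound 3 (0.24 log units; within the scatter), so with the nitro group present this exchange does not move the number beyond the scatter. Nitro in place of hydrogen on an aromatic carbon, with the thiophen-2-yl group kept, gives a 3.2-fold lower number from compound 1 to compound 3 (0.50 log units; beyond the scatter), a modest step beyond the scatter. Of the two changes, only the nitro group therefore shifts the number beyond the scatter in these compounds, and nothing given here explains either step.

From the compounds shown here alone, it remains open whether the nitro group would give a step of similar size with methyl on the carbonyl carbon. Going by these compounds, it is also open how an amine or a longer alkyl chain on that carbonyl carbon would compare with methyl and thiophen-2-yl.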